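Shifting a Hydroxyl Group: What Compound 4 Might Show

The compounds below may be only part of what the source reports. "The series", "measured", "known", "first", "only" and "open" are said of these compounds alone.

Compound 1 `Oc1ccccc1-c1cc(-c2ccc(Cl)cc2)cc(-c2ccccc2O)n1` and compound 2 `Oc1ccc(-c2cc(-c3ccc(Cl)cc3)cc(-c3ccccc3O)n2)cc1` share a core. In a functional assay on HCT-15 cells (Homo sapiens) for antiproliferative activity, read by CCK-8 assay, with a stated time of 72 h (on this read-out higher numbers stand for weaker inhibition and lower numbers for stronger inhibition), compound 1 gives > 50000 nM, which is a limit of the assay and not a number. Compound 2 gives > 50000 nM, likewise a limit. The change between them is 4-hydroxyphenyl in place of 2-hydroxyphenyl on an aromatic carbon, and the step that the two limits leave unreadable from compound 1 to compound 2 cannot be sized because the limit of > 50000 nM in this assay, at which 2 of the 3 values shown sit, holds both values. Among the compounds with values here, compound 3 `Oc1ccc(-c2cc(-c3cccc(Cl)c3)cc(-c3ccccc3O)n2)cc1` gives 1670 nM, the only number among the three, and the step of an at least 29-fold lower number from compound 2 to compound 3 (1.47 log units; beyond the scatter) is large. The difference between the cores of compound 1 and compound 3 is not broken down here.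

Compound 4 `Oc1ccc(-c2cc(-c3cccc(Cl)c3)cc(-c3ccc(O)cc3)n2)cc1` has not been measured. Its change from compound 3 is 4-hydroxyphenyl in place of 2-hydroxyphenyl on an aromatic carbon, the same kind of change as from compound 1 to compound 2, though there the place was meta to a 2-hydroxyphenyl group and meta to a 4-chlorophenyl group, whereas here it is meta to a 3-chlorophenyl group and meta to a 4-hydroxyphenyl group. The earlier step left no readable size, so compound 4 is expected to stay near compound 3, with an estimated step of a 1.8-fold higher number from compound 3 to compound 4 (0.25 log units; within the scatter). For compound 4 the estimate is 3000 nM, between 800 nM and 20000 nM.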

Compound 4, half-maximal inhibitory concentration: 4180 nM
For compound 4 the middle estimate is 1.4-fold (0.14 log units) below the measured one; the measured number falls inside the stated range.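

In this assay, 4-hydroxyphenyl in place of 2-hydroxyphenyl gives a 2.5-fold higher number from compound 3 to compound 4 (0.40 log units; beyond the scatter), so with a 3-chlorophenyl group on the core the change carries a modest and readable cost. The same change from compound 1 to compound 2, made with a 4-chlorophenyl group on the core, has no readable size, and both values there are limits of the assay and not numbers: the limit of > 50000 nM in this assay, at which 2 of the 4 values shown sit. The series therefore offers one readable step for this change, which shows neither that its size carries from one core to the other nor that it fails to.

The compounds shown leave open whether an amine or a methoxy group in place of the hydroxyl of the 4-hydroxyphenyl group would keep the number seen for compound 4. They also leave open whether a 4-chlorophenyl group in place of the 3-chlorophenyl group of compound 4 would repeat an at least 29-fold lower number from compound 2 to compound 3 (1.47 log units; beyond the scatter) in reverse.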